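Swapping the thiazole on the amine for a triazoline ring

The source may hold more compounds than are shown below. What is called first, only, known or untested is meant among the compounds shown, and "the series" means these compounds.

Three esters of the same coumarin-type core have been tested in a functional assay on the whole organism (strain Wistar albino) for inhibition, with Rattus norvegicus as the target, read by paw edema, with stated times of 30 min and 1 h, at a dose of 20 mg/kg by the oral route; on this read-out lower numbers stand for less inhibition and higher numbers for more inhibition at the one dose given (going by the name of the read-out). Compound 1 `COc1ccc(NCC(=O)Oc2ccc3c(C)cc(=O)oc3c2)cc1` gives 30.3%. Compound 2 `COc1ccccc1NCC(=O)Oc1ccc2c(C)cc(=O)oc2c1`, carrying a 2-methoxyphenyl instead of a 4-methoxyphenyl on the amine nitrogen, gives 10.7%, so that a number 19.6 percentage points lower from compound 1 to compound 2 (beyond the scatter). Compound 3 `Cc1cc(=O)oc2cc(OC(=O)CNc3nccs3)ccc12`, with a 1,3-thiazol-2-yl on that nitrogen, gives 39.2%; here a number 8.9 percentage points higher from compound 1 to compound 3 (within the scatter), whereas a number 28.5 percentage points higher from compound 2 to compound 3 (beyond the scatter). Compound 3 thus holds the top number of the three, but its gap to compound 1 is within the scatter, so only compound 2 is clearly set apart from it.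

Compound 4 `Cc1cc(=O)oc2cc(OC(=O)CNN3C=NNC3)ccc12` is not yet measured. It differs from compound 3 in one place: a group of 5 heavy atoms (2 carbon, 3 nitrogen; one five-membered non-aromatic ring with 3 hetero atoms) in place of a group of 5 heavy atoms (3 carbon, 1 nitrogen, 1 sulfur; one five-membered aromatic ring with 2 hetero atoms), on an amine nitrogen. Every measured step also changed the group on this amine nitrogen, and those steps ranged from within the scatter to modest in size. None of them exchanged an aromatic ring for a non-aromatic one, so the direction is uncertain; a modest drop or no change beyond the scatter seems the likeliest outcome. Compound 4 is therefore expected to give about 30%, between 15% and 45%, which would mean an estimated a number 9.2 percentage points lower from compound 3 to compound 4 (within the scatter).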

Compound 4, a percentage reported as inhibition, in the whole organism at one dose (the size of the read-out at that dose, not a potency): 42.8%
Compound 4: middle estimate off by 12.8 percentage points, on the low side; the range from low to high includes it.
By their numbers in this assay, from the lowest: compound 2; then compounds 1, 3 and 4 (each within the scatter of the next, the first and the last beyond it).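

In this assay, the amine nitrogen carries the non-aromatic five-membered ring with 3 hetero atoms as readily as it carries 1,3-thiazol-2-yl: the exchange gives a number 3.6 percentage points higher from compound 3 to compound 4 (within the scatter), so an aromatic ring on this nitrogen is not required to keep the read-out at the level of compound 3. The thiazole of compound 3 could not be separated from the 4-methoxyphenyl group of compound 1, but the new ring stands clear of both methoxyphenyl groups, with a number 12.5 percentage points higher from compound 1 to compound 4 (beyond the scatter) and a number 32.1 percentage points higher from compound 2 to compound 4 (beyond the scatter). Nothing available explains why these groups on the nitrogen compare as they do.

Still open, from the compounds shown here alone, is whether the hetero atoms of the five-membered rings matter at all, which a plain cyclopentyl ring on the same nitrogen could help to show, and how a six-membered morpholine ring would compare. All these numbers also come from a single oral dose, so they leave open whether the same gaps would appear at other doses.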